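The source may hold more compounds than are shown below. What is called first, only, known or untested is meant among the compounds shown, and "the series" means these compounds.

Compound 1 `COC(=O)c1cc(S(N)(=O)=O)ccc1S(=O)(=O)CCO` and compound 2 `COC(=O)c1cc(S(N)(=O)=O)ccc1S(=O)(=O)CCCO` share one core. In a physicochemical assay for acid dissociation, compound 1 gives 9.2 and compound 2 gives 8.9, a step of a number 0.30 log units lower from compound 1 to compound 2 (within the scatter) for the change (hydroxymethyl in place of hydroxy on a saturated chain carbon, two bonds along the chain from a sulfonyl sulfur). Compound 3 `NS(=O)(=O)c1ccc(SCCCO)s1` is built on a different core; how the two cores differ is not broken down here. In this assay compound 3 gives 9.32. Compound 4 `NS(=O)(=O)c1ccc(SCCCCO)s1` has not yet been measured and differs from compound 3 by hydroxymethyl in place of hydroxy on a saturated chain carbon, three bonds along the chain from a sulfur, the same kind of change as the earlier one, though here the place is three bonds along the chain from a sulfur rather than two bonds along the chain from a sulfonyl sulfur. The earlier change gave a number 0.30 log units lower from compound 1 to compound 2 (within the scatter). On that basis the expected step here is a number 0.17 log units lower from compound 3 to compound 4 (within the scatter), small. Compound 4 is expected to give 9.15 in this assay, likely between 8.75 and 9.55.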

Compound 4, acid dissociation constant: 9.5
Estimate against measurement, compound 4: 0.35 log units below, and the stated range covers the measured number.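

In this assay the change from hydroxy to hydroxymethyl gives a number 0.18 log units higher from compound 3 to compound 4 (within the scatter) on one core and a number 0.30 log units lower from compound 1 to compound 2 (within the scatter) on the other, so on both cores the step stays within the scatter. This shows that the change carried across the two cores without a step beyond the scatter, but with a single pair on each core, and a different place on the chain, it does not establish a real difference in direction or a shared effect. Nothing measured here bears on why the numbers lie where they do.

Still open, going by these compounds, is whether the step stays this small when a carboxylic acid or an amine replaces the hydroxy, or on a chain longer than 4-hydroxybutyl. Also open, on these data alone, is whether a sulfonyl sulfur in place of the sulfur on the core of compound 3 would give a similar step, a comparison that would tell the core apart from the place.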